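A few compounds are considered here, and "the series" means these few. Any claim that something is new, unique, unknown or untested is made for them only; others in the source may bear on it.

In a physicochemical assay for solubility, read by chemiluminescence (on this read-out higher numbers stand for higher solubility and lower numbers for lower solubility), three compounds have been measured so far. Compound 1 (`O=C(CN(C(=O)c1cccnc1)C1CCCCC1)Nc1cc(F)cc(F)c1`) gives 160 ug/mL and stands apart from the other two. Compound 2 (`COc1ccc(C(=O)N(Cc2[nH]ncc2-c2ccccc2)C2CCCCC2)cc1`) gives 42 ug/mL on the same read-out. Compound 3 (`O=C(CN(CC1CC1)C(=O)c1ccc(-c2ccccn2)cc1)Nc1cc(F)cc(F)c1`) gives 25 ug/mL and so lies within the scatter of compound 2, but well beyond the scatter from compound 1, which shows the higher number.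

Compound 4 (`COCC(C)N(CC(=O)Nc1cc(F)cc(F)c1)C(=O)c1ccc(-c2ccccn2)cc1`) has not yet been measured. It differs from compound 3 in one place, with 1-(methoxymethyl)ethyl in place of cyclopropylmethyl on an amide-type nitrogen. For the measured compounds named here, no two measured compounds differ in only one place, so this assay offers no direct precedent for this change. Starting from compound 3 at 25 ug/mL and with only three measured values as a guide, a small upward move is expected. The expected move is a 1.6-fold higher number from compound 3 to compound 4 (0.20 log units; within the scatter) and remains within the scatter. For compound 4 the estimated value is 40 ug/mL with an expected range from 15 ug/mL to 110 ug/mL as the likely span.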

Compound 4, solubility: 58 ug/mL
Compound 4: the middle estimate sits 1.5-fold (0.16 log units) below what was measured; the measured number falls inside the stated range.
By their numbers in this assay, from the lowest: compounds 3, 2 and 4 (each within the scatter of the next, the first and the last beyond it); then compound 1.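

In this assay, for the compounds shown here, the group on this amide-type nitrogen proves able to shift the read-out on its own: 1-(methoxymethyl)ethyl in place of cyclopropylmethyl gives a 2.3-fold higher number from compound 3 to compound 4 (0.37 log units; beyond the scatter), the first comparison in this set in which only one place differs. The change removes a three-membered ring of carbon only and adds an oxygen and a hydrogen-bond acceptor, with the rest of the structure held constant. No measurement shown accounts for the rise, and this single pair does not separate the loss of the ring from the arrival of the oxygen.

The compounds shown leave open how a 2-methoxyethyl chain, an isopropyl group or an open-chain carbon group without oxygen would read at this nitrogen. They also leave open how an amine or a carboxylic acid would read there.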